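The source may hold more compounds than are shown below. What is called first, only, known or untested is meant among the compounds shown, and "the series" means these compounds.

Compound 1 `CC(Oc1cccnc1Nc1cnn(C)c1)c1cccc(C(=O)NCc2ccc(Cl)c(C(F)(F)F)c2)c1` gives 48600 nM in a functional assay on HCC78 cells (Homo sapiens) for antiproliferative activity, read by MTT assay, with a stated time of 48 h; a higher number here means a weaker inhibitor, a lower number a stronger inhibitor.
Compound 2 `Cc1ccc(CNC(=O)c2cccc(C(C)Oc3cccnc3Nc3ncccn3)c2)cc1` reaches only the limit of this assay, > 100000 nM.
Compound 3 `Cc1ccc(CNC(=O)c2cccc(C(C)Oc3cccnc3Nc3cnn(CC(C)(C)O)c3)c2)cc1` gives 20500 nM in this assay.

Among the two compounds with a numerical result, compound 3 stands lowest; the number of compound 1 lies beyond the scatter from it, and the value of compound 2 is a limit. Going by the values given here, the one measured step, an at least 4.8-fold lower number from compound 2 to compound 3 (0.68 log units; beyond the scatter), is the change from the pyrimidinyl to the hydroxy-bearing pyrazolyl on the nitrogen on the aromatic ring, and its size is bounded only from one side because of the limit of > 100000 nM in this assay, at which 1 of the 3 values shown sits.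

Compound 4 `Cc1ccc(CNC(=O)c2cccc(C(C)Oc3cccnc3Nc3cnn(CC#N)c3)c2)cc1` differs from compound 3 by cyano in place of 1-hydroxy-1-methylethyl on a saturated chain carbon bound to an aromatic nitrogen. Among the compounds with values here, the pyrazole itself is kept, so no measured step in this assay probes the substituent on the pyrazole nitrogen; the step from compound 2 to compound 3 changes the whole ring and does not carry over. Compound 4 is therefore expected to show no step beyond the scatter relative to compound 3. The estimate for compound 4 in this assay is 25000 nM, with a range from 8000 nM to 80000 nM. This estimate means a 1.2-fold higher number from compound 3 to compound 4 (0.09 log units; within the scatter).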

Compound 4, half-maximal inhibitory concentration: 57400 nM
Estimate against measurement, compound 4: 2.3-fold (0.36 log units) below; low and high end bracket the measured number.
By their numbers in this assay, from the lowest: compound 3; then compounds 1 and 4 (each within the scatter of the next). At a limit, above all of these: compound 2.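

In this assay the group on a saturated chain carbon bound to an aromatic nitrogen is now shown to count: cyano in place of 1-hydroxy-1-methylethyl gives a 2.8-fold higher number from compound 3 to compound 4 (0.45 log units; beyond the scatter) and is the first measured step at this place. Set against pyrimidin-2-yl, 1-(cyanomethyl)-1H-pyrazol-4-yl gives an at least 1.7-fold lower number from compound 2 to compound 4 (0.24 log units; that floor lies within the scatter), a floor that shows no gain beyond the scatter. Compound 2 stands at a limit, and this step therefore has only a floor: the limit of > 100000 nM in this assay, at which 1 of the 4 values shown sits.

The compounds shown do not separate the hydroxy group from the chain that carries it, since 2-hydroxy-2-methylpropyl and cyanomethyl differ in both. On these data alone, how a primary amine, a carboxylic acid or a longer chain ending in a hydroxy group would read at this place in this assay stays open.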